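The source may hold more compounds than are shown below. What is called first, only, known or untested is meant among the compounds shown, and "the series" means these compounds.

Measured in a functional assay on NCI-H460 cells (Homo sapiens); a lower number here means a stronger inhibitor, a higher number a weaker inhibitor:

- compound 1 `COc1cc(NC(C)CCCNC(=O)NC(CO)(CO)CO)c2ncccc2c1`: > 100000 nM
- compound 2 `COc1cc(NC(C)CCCNC(=O)NO)c2ncccc2c1`: > 100000 nM

Both entries are limits of the assay, not numbers.

In this assay, compound 2 stands at > 100000 nM, which is a limit. Within the data shown here, it therefore has no readable position, and the same is true of the only other compound measured so far. Compound 3 `COC(=O)NCCCC(C)Nc1cc(OC)cc2cccnc12` has not yet been measured. It differs from compound 2 in one place, with methoxy in place of hydroxyamino on a carbonyl carbon.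

Among the measured compounds shown here, only one measured step bears on this change, a step that the two limits leave unreadable from compound 1 to compound 2. Its size cannot be read, so it offers no guide to size or direction. What it does show is the limit of > 100000 nM in this assay, at which 2 of the 2 values shown sit, and neither of the two changes at that end of the molecule has yet given a number. No step beyond the scatter is therefore expected in this assay, and compound 3 will most likely report a limit too. The expected change is an at least 1.1-fold lower number from compound 2 to compound 3 (0.04 log units; that floor lies within the scatter), a rough figure. Compound 3 is estimated at 90000 nM, with an expected range from 30000 nM to 150000 nM.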

Compound 3, half-maximal inhibitory concentration: > 100000 nM
Compound 3 ended at the assay's limit (the forecaster's own chance of this, stated with the estimate: 65%); middle value at least 1.1-fold (0.04 log units) from the limit.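

In this assay compound 3 gives > 100000 nM as a limit, not a number. Among these compounds, no step among compound 1, compound 2 and compound 3 can be read: the limit of > 100000 nM in this assay, at which 3 of the 3 values shown sit.

The compounds shown leave open whether any change at this end of the molecule gives a readable value in this assay.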